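The source may hold more compounds than are shown below. What is called first, only, known or untested is meant among the compounds shown, and "the series" means these compounds.

Compounds measured in an ADME assay on MT4 cells (Homo sapiens) for cytotoxicity, read by MTT assay (a lower number here means that less compound is tolerated, a higher number that more compound is tolerated), so far:
compound 1, `CCOC(=O)/C(O)=C/C(=O)c1cn(Cc2cc(F)c(F)c(F)c2)c2cccc(OC)c12`, gives 33400 nM
compound 2, `CCOC(=O)/C(O)=C/C(=O)c1cn(Cc2cc(F)cc(F)c2)c2cccc(OC)c12`, gives 34700 nM
compound 3, `COc1cccc2c1c(C(=O)/C=C(\O)C(=O)O)cn2Cc1cccc(F)c1F`, gives 17500 nM

Compound 4, `COc1cccc2c1c(C(=O)/C=C(\O)C(=O)O)cn2Cc1ccccc1F`, has not yet been measured in this assay. It is reached from compound 3 by hydrogen in place of fluoro on an aromatic carbon. The same kind of change separates compound 1 from compound 2, (hydrogen in place of fluoro on an aromatic carbon), where the position is ortho to two fluoro groups and para to a large group rather than ortho to a fluoro group and meta to a large group. That earlier step gave a 1.0-fold higher number from compound 1 to compound 2 (0.02 log units; within the scatter). The difference between the two cores is not broken down here. Resting on that earlier step, the step of a 1.0-fold higher number from compound 3 to compound 4 (0.01 log units; within the scatter) is expected to stay small. Compound 4 is therefore estimated at 18000 nM, between 9000 nM and 36000 nM.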

Compound 4, half-maximal cytotoxic concentration: 70500 nM
The estimate for compound 4 lay 3.9-fold (0.59 log units) below the measured number; the measured number lies above the stated range.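

In this assay, the change from 2,3-difluorobenzyl to 2-fluorobenzyl gave a 4.0-fold higher number from compound 3 to compound 4 (0.61 log units; beyond the scatter), so replacing a fluoro with hydrogen did not carry the same result from one core to the other: the same change on two cores in this assay, a 1.0-fold higher number (0.02 log units; within the scatter) from compound 1 to compound 2 and a 4.0-fold higher number (0.61 log units; beyond the scatter) from compound 3 to compound 4, 3.9-fold (0.59 log units) apart, beyond the scatter of two such steps

This does not show what separates the two steps, since the pairs differ both in their core and in where the fluoro group leaves the ring. With one step on each core, it also gives no general rule for this change in the series.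

The compounds shown leave open how the same replacement would read at other places on the ring of each core. They also leave open how a chloro group or an amine would compare with fluoro at this place.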